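Replacing an Aryl Ether with a Benzyl Group: Cytotoxicity Outlook

This account rests on a few compounds, and the source may have more. Where it says the series, first, only, none or still open, it means among the compounds named here.

Of the compounds shown here, three have so far been measured in an ADME assay on HepG2 cells (Homo sapiens) for cytotoxicity, read by luminescence, CellTiter-Glo and ATP content, with a stated time of 72 h; on this read-out higher numbers stand for an effect only at larger amounts of compound and lower numbers for an effect already at smaller amounts. Compound 1 `COc1ccccc1Oc1ccc2c(NCCCNCc3ccco3)ccnc2c1` gives 6500 nM, the highest of the three numbers. Compound 3 `COc1ccc(Oc2ccc3c(NCCCNCc4cccc(OC)c4O)ccnc3c2)cc1` gives 5500 nM, which lies within the scatter of compound 1, while compound 2 `COc1ccc(F)cc1CNCCCNc1ccnc2cc(Cc3cc(C)cc(C)c3)ccc12` gives 940 nM, well beyond the scatter below compound 1. Compound 4 `Fc1ccc(Cc2ccc3c(NCCCNCc4ccco4)ccnc3c2)c(Cl)c1` has not yet been measured. It differs from compound 1 in a single place: 2-chloro-4-fluorobenzyl in place of 2-methoxyphenoxy on an aromatic carbon. Going by the values given here, no measured pair isolates this change. The value of compound 2, 940 nM, shows that a benzyl-bearing member of this series can sit far below compound 1. Against that background compound 4 is expected to move downward by a moderate step, a 3.0-fold lower number from compound 1 to compound 4 (0.47 log units; beyond the scatter), beyond the scatter. Compound 4 is estimated at 2200 nM, within a range from 700 nM to 6500 nM.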

Compound 4, half-maximal effective concentration: 5730 nM
Estimate against measurement, compound 4: 2.6-fold (0.42 log units) below, and the stated range covers the measured number.
By their numbers in this assay, from the lowest: compound 2; then compounds 3, 4 and 1 (each within the scatter of the next).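

In this assay, going by these compounds alone, placing 2-chloro-4-fluorobenzyl in place of 2-methoxyphenoxy on this aromatic carbon gives a 1.1-fold lower number from compound 1 to compound 4 (0.05 log units; within the scatter), the first step here that isolates a change at this position. The exchange keeps the count of 9 heavy atoms and replaces a group with 2 hydrogen-bond acceptors by one with 0, yet the number stays within the scatter. Nothing available accounts for this result. On these data alone, whether an amine or a carboxylic acid on this aromatic carbon would also leave the number within the scatter remains open. So does whether the same exchange would behave alike with a different group at the end of the side chain.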